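From pyrimidin-5-yl to 3,5-dimethyl-1,2-oxazol-4-yl at the assay limit

The source may report more compounds than this note shows. Statements on the series, on what has been measured and on what is new or still open speak of the compounds shown alone.

In an ADME assay on J774 cells (Mus musculus) for cytotoxicity, with a stated time of 72 h (a lower number here means that less compound is needed, a higher number that more compound is needed for the effect), compound 1 `COc1cc2[nH]c(C)c(-c3ccccn3)c(=O)c2cc1Cl` gives > 33300 nM as a limit and not a number. Compound 2 `COc1cc2[nH]c(C)c(-c3cncnc3)c(=O)c2cc1Cl` gives > 33100 nM as a limit too. Compound 3 `COc1cc2[nH]c(C)c(-c3ccc(N4CCN(C)CC4)nc3)c(=O)c2cc1Cl` gives > 25100 nM as a limit as well. Compound 2 therefore stands, like the other two, at a limit, with no number of its own.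

Compound 4 `COc1cc2[nH]c(C)c(-c3c(C)noc3C)c(=O)c2cc1Cl` carries 3,5-dimethyl-1,2-oxazol-4-yl in place of pyrimidin-5-yl. Counted out, the change is 3,5-dimethyl-1,2-oxazol-4-yl in place of pyrimidin-5-yl on an aromatic carbon and it sits on an aromatic carbon, ortho to a methyl group. Among the compounds with values here, the one measured step at that carbon is a step that the two limits leave unreadable from compound 1 to compound 2 with pyrimidin-5-yl in place of pyridin-2-yl, so it offers no size to carry over.

No step beyond the scatter is expected in this assay and no direction can be given. The estimate rests on compound 2 with > 33100 nM as its limit. The expected step is a number no higher from compound 2 to compound 4 (the limit leaves the size open) by this estimate. Another limit is the likeliest report. Compound 4 is expected near 33000 nM with an estimated range of 15000 nM to 70000 nM as its ends.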

Compound 4, half-maximal effective concentration: > 31400 nM
Compound 4 was reported as a limit; the forecaster's own chance of this, stated with the estimate: 85%; the middle value lies beyond the limit too.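

In this assay compound 4 gives > 31400 nM, a limit and not a number. Compound 1 and compound 2 also stand at limits, so neither step to compound 4 can be read. The compounds shown leave open what half-maximal effective concentration any of them actually has.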